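The source may report more compounds than this note shows. Statements on the series, on what has been measured and on what is new or still open speak of the compounds shown alone.

Three compounds share one core and differ only in the aryl group carried on the sulfonyl sulfur. Compound 1 `Cc1ccc2ncc(S(=O)(=O)c3ccc(Cl)cc3)c(N3CCC(C)CC3)c2c1` carries 4-chlorophenyl, and in an assay on isolated protein for displacement of a labelled ligand from metabotropic glutamate receptor 5 (Homo sapiens), with a stated time of 60 min, tested at 1 uM (on this read-out higher numbers stand for more inhibition at the one concentration tested (going by the name of the read-out) and lower numbers for less inhibition), compound 1 gives 79%. Compound 2 `Cc1ccc2ncc(S(=O)(=O)c3ccc(C)c(F)c3)c(N3CCC(C)CC3)c2c1` carries 3-fluoro-4-methylphenyl, and in this assay compound 2 gives 91%. Compound 3 `Cc1ccc2ncc(S(=O)(=O)c3cccc(Cl)c3)c(N3CCC(C)CC3)c2c1` carries 3-chlorophenyl, and in this assay compound 3 gives 91%. Compound 3 thus stands level with compound 2, the pair together forming the highest of the three numbers, while compound 1 lies lower: a number 12 percentage points higher from compound 1 to compound 3 (beyond the scatter), and no change at the digits printed from compound 2 to compound 3 (within the scatter).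

Compound 4 `Cc1ccc2ncc(S(=O)(=O)c3ccc(Cl)c(Cl)c3)c(N3CCC(C)CC3)c2c1` takes one further step from compound 3: chloro in place of hydrogen on an aromatic carbon. Cut one bond further out, the change reads 3-chlorophenyl to 3,4-dichlorophenyl. Within the data shown here, two measured steps bear on it. Exchanging 4-chlorophenyl for 3-chlorophenyl gave a number 12 percentage points higher from compound 1 to compound 3 (beyond the scatter), and exchanging 3-fluoro-4-methylphenyl for 3-chlorophenyl gave no change at the digits printed from compound 2 to compound 3 (within the scatter); compound 2, whose phenyl carries two groups, holds the same level as compound 3. Since compound 4 keeps its 3-chloro group, a step of a number 3 percentage points lower from compound 3 to compound 4 (within the scatter) is expected, within the scatter. Compound 4 is therefore estimated at 88%, lying between 76% and 97%.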

Compound 4, a percentage reported as inhibition, at one concentration (the size of the read-out at that concentration, not a potency): 82%
Estimate against measurement, compound 4: 6 percentage points above, and the stated range covers the measured number.
By their numbers in this assay, from the lowest: compounds 1, 4, 2 and 3 (each within the scatter of the next, the first and the last beyond it).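

Putting chloro on this aromatic carbon, ortho to a chloro group and para to a large group, gives a number 9 percentage points lower from compound 3 to compound 4 (within the scatter) and exchanging the aryl group of compound 2 for 3,4-dichlorophenyl gives a number 9 percentage points lower from compound 2 to compound 4 (within the scatter) so a phenyl with two groups on it holds up here as it did in compound 2. Adding chloro gives a number 3 percentage points higher from compound 1 to compound 4 (within the scatter) whereas exchanging the aryl group for 3-chlorophenyl gives a number 12 percentage points higher from compound 1 to compound 3 (beyond the scatter) so compound 4 sits within the scatter of two compounds that lie beyond the scatter of each other, and it cannot be assigned to either level. Nothing available explains these numbers.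

From the compounds shown here alone, whether a methoxy group, a nitrile or an amine on this same carbon would read differently in this assay stays open. A single concentration also leaves open how these compounds would compare across a range of concentrations.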